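Arylpiperazine series: whole-animal antagonist potency, chlorinated versus unsubstituted analogue

The compounds below may be only part of what the source reports. "The series", "measured", "known", "first", "only" and "open" are said of these compounds alone.

Measured so far:
compound 1, `C1=C(CCN2CCN(c3cccc4c3OCCO4)CC2)c2ccccc2CC1`, 0.63 mg/kg
compound 2, `Clc1cccc2c1CC2CCN1CCN(c2cccc3c2OCCO3)CC1`, 1.25 mg/kg
compound 3, `COc1cc2c(cc1OC)C(CCN1CCN(c3cccc4c3OCCO4)CC1)CC2`, 2.5 mg/kg

The read-out is a functional assay on the whole organism for antagonist activity, with Rattus norvegicus as the target; a higher number here means that more compound is needed for the effect, a lower number that less compound is needed. Compound 2 stands second highest of the three numbers; its nearest neighbour is compound 1 and its furthest is compound 3, and both of those gaps lie within the usual scatter, so the three compounds are not separable on these data.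

Compound 4, `c1ccc2c(c1)CC2CCCN1CCN(c2cccc3c2OCCO3)CC1`, is not yet measured. It differs from compound 2 by a group of 9 heavy atoms (9 carbon; one four-membered non-aromatic ring of carbon only, one six-membered aromatic ring of carbon only) in place of a group of 9 heavy atoms (8 carbon, 1 chlorine; one four-membered non-aromatic ring of carbon only, one six-membered aromatic ring of carbon only), on a saturated chain carbon, two bonds along the chain from an amine nitrogen in a ring.

Within the data shown here, no step between two measured compounds isolates this kind of change, so the expectation rests only on the spread of the three numbers, which is narrow. The step from compound 2 to compound 4 is expected to be small, a 1.3-fold lower number from compound 2 to compound 4 (0.10 log units; within the scatter), and not clearly beyond the scatter in either direction. Compound 4 is therefore estimated at 1 mg/kg, in the range 0.4 mg/kg to 3 mg/kg.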

Compound 4, minimum effective dose: 0.16 mg/kg
For compound 4 the middle estimate is 6.3-fold (0.80 log units) above the measured one; measured number outside the range, below it.
By their numbers in this assay, from the lowest: compound 4; then compounds 1, 2 and 3 (each within the scatter of the next, the first and the last beyond it).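

In this assay the exchange of the group of 9 heavy atoms holding 8 carbon and 1 chlorine for the all-carbon group of 9 heavy atoms, on a saturated chain carbon, gives a 7.8-fold lower number from compound 2 to compound 4 (0.89 log units; beyond the scatter) and so moves beyond the scatter. Among these compounds, the earlier compounds offered no step, so this is the first sign that this position responds to change. Nothing available bears on the reason for this step. On these data alone, whether the chlorine or the extra carbon carries the step stays open, as does the effect of a fluorine in place of that chlorine or of a longer chain.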